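The compounds below may be only part of what the source reports. "The series", "measured", "known", "first", "only" and "open" are said of these compounds alone.

Measured compounds in a functional assay on L1210 cells (Mus musculus) for cytotoxicity; on this read-out lower numbers stand for an effect already at smaller amounts and higher numbers for an effect only at larger amounts of compound:
compound 1 `COc1cc(C(C)O)c(OC)c2c1C(=O)C=CC2=O`, with 0.132 ug/mL;
compound 2 `CCCCCC(O)c1cc(OC)c2c(c1OC)C(=O)C=CC2=O`, with 0.066 ug/mL.

Of the two numbers in this assay, compound 2 gives the lower, though the gap to compound 1 is within the scatter. The next compound, compound 3 `CCC(O)c1cc(OC)c2c(c1OC)C(=O)C=CC2=O`, is not yet measured. It differs from compound 2 by hydrogen in place of propyl on a saturated chain carbon, three bonds along the chain from an aromatic carbon and an oxygen on a saturated carbon, so the 1-hydroxyhexyl side chain of compound 2 becomes a 1-hydroxypropyl side chain; compound 3 thus stands between compound 1 and compound 2 in chain length. Among the compounds with values here, the only step that bears on this is the one along the same chain, a 2.0-fold lower number from compound 1 to compound 2 (0.30 log units; within the scatter), which did not rise above the scatter. Lengthening by butyl changed nothing beyond noise, so shortening by propyl is expected to give a step of a 1.4-fold higher number from compound 2 to compound 3 (0.13 log units; within the scatter) that also stays within the scatter. Compound 3 is therefore estimated at 0.09 ug/mL, with a range from 0.04 ug/mL to 0.2 ug/mL.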

Compound 3, concentration for half-maximal effect: 0.085 ug/mL
Estimate against measurement, compound 3: 1.1-fold (0.02 log units) above; the measured number falls inside the stated range.
By their numbers in this assay, from the lowest: compounds 2, 3 and 1 (each within the scatter of the next).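

In this assay, hydrogen in place of propyl on this saturated chain carbon gives a 1.3-fold higher number from compound 2 to compound 3 (0.11 log units; within the scatter) and methyl in place of hydrogen two bonds along the chain from an aromatic carbon gives a 1.6-fold lower number from compound 1 to compound 3 (0.19 log units; within the scatter) and both steps stay within the scatter. The side chain now has a third length, and the intermediate 1-hydroxypropyl chain adds no step beyond the scatter, so among compound 1, compound 2 and compound 3 the numbers do not separate by chain length. No measurement at hand bears on why chain length leaves the number within the scatter.

Open, from the compounds shown here alone, is whether a longer chain, such as dodecyl, would give a step beyond the scatter. Also open, going by these compounds, is what an amine or a carboxylic acid in place of the hydroxy of the 1-hydroxypropyl side chain would do.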